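Adding Chloro to the Bromo-Bearing Ring: Expected Inhibition

The source may report more compounds than this note shows. Statements on the series, on what has been measured and on what is new or still open speak of the compounds shown alone.

Compound 1 `Nc1nc(N)nc(-c2ccccc2Br)n1` carries a bromo group on a six-membered aromatic ring of carbon only, attached to the shared core. Among the compounds with values here, in a functional assay on the whole organism with Rattus norvegicus as the target, at a dose of 20 mg/kg by the intraperitoneal route (a higher number here means more inhibition at the dose given (going by the name of the read-out), a lower number less inhibition), compound 1 gives 26%, the higher of the two numbers measured so far. Compound 2 `Nc1nc(N)nc(-c2ccccc2[N+](=O)[O-])n1`, made by nitro in place of bromo on an aromatic carbon, gives 11%; the step is a number 15 percentage points lower from compound 1 to compound 2 (beyond the scatter). Compound 3 `Nc1nc(N)nc(-c2cc(Cl)ccc2Br)n1` has not been measured; it differs from compound 1 by chloro in place of hydrogen on an aromatic carbon. Within the data shown here, the only measured step exchanges the bromo group itself, whereas here the bromo group stays and a chloro group is added, so no measured step bears directly on this change. With nothing to go on, the expected step is a number 2 percentage points higher from compound 1 to compound 3 (within the scatter), that is, none beyond the scatter. Compound 3 is therefore estimated to give 28% in this assay, with a range from 10% to 46%.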

Compound 3, a percentage reported as inhibition, in the whole organism at one dose (the size of the read-out at that dose, not a potency): 81%
Beside the measured number, compound 3's estimate is 53 percentage points below it; measured number above the stated range.
By their numbers in this assay, from the lowest: compound 2; then compound 1; then compound 3.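

In this assay, chloro in place of hydrogen on the aromatic carbon para to the bromo group gives a number 55 percentage points higher from compound 1 to compound 3 (beyond the scatter), so a single added atom at this position can move the read-out a long way. Within the data shown here, the only earlier step exchanged the bromo group itself and lowered the number, whereas this one leaves the bromo group in place and shows that a change elsewhere on the same ring can raise it. No measurement here accounts for a rise of this size.

On these data alone, it remains open whether this rise belongs to chloro itself or would also come with another group on this carbon, such as a fluoro, a methoxy group, an amine or a carboxylic acid. As far as these compounds go, it is also open whether chloro at this position would raise the number when nitro stands in place of bromo, as in compound 2.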